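Replacing Chloro with Fluoro in a Weaker Growth Inhibitor

This account rests on a few compounds, and the source may have more. Where it says the series, first, only, none or still open, it means among the compounds named here.

Among the measured compounds shown here, only two compounds have been measured so far. In a functional assay on CAL-51 cells (Homo sapiens) for inhibition, read by sulforhodamine B assay, with a stated time of 3 days (a lower number here means a stronger inhibitor of growth, a higher number a weaker inhibitor of growth), compound 1 `O=C(/C=C/c1cccc([N+](=O)[O-])c1)c1ccccc1` gives 1080 nM, while compound 2 `O=C(/C=C/c1ccc(Cl)cc1)c1ccccc1` gives 5850 nM. Compound 2 therefore has the higher of the two numbers, making it the weaker growth inhibitor of the pair, and the gap between them lies beyond the usual scatter. These two compounds carry different groups, so their gap does not show what a single small replacement would do.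

The next compound stays close to compound 2. Compound 3 `O=C(/C=C/c1ccc(F)cc1)c1ccccc1` differs from it by one change: fluoro in place of chloro on an aromatic carbon. The rest of the structure remains the same. For the measured compounds named here, with no measured single-change step to draw on, the starting point is compound 2 at 5850 nM. The expected change is small, a 1.2-fold higher number from compound 2 to compound 3 (0.08 log units; within the scatter), with no shift beyond the scatter. In this assay, compound 3 is estimated at 7000 nM, with an expected range of 2800 nM to 17000 nM.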

Compound 3, concentration for 50% growth inhibition: 2780 nM
Estimate against measurement, compound 3: 2.5-fold (0.40 log units) above, and the stated range ends above it.
By their numbers in this assay, from the lowest: compound 1; then compound 3; then compound 2.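

Among the compounds shown here, the swap of chloro for fluoro on an aromatic carbon, para to a large group, is the first single change that can be read in this assay and gives a 2.1-fold lower number from compound 2 to compound 3 (0.32 log units; beyond the scatter) as a modest step that lies beyond the usual scatter. This shows that replacing one atom at this position, with the rest of the structure unchanged, can shift growth inhibition measurably, and that here fluoro gives the stronger inhibitor of the two. The gap between compound 1 and compound 2 could not show this, since those compounds carry different groups; nothing measured here explains why the step runs in this direction.

From the compounds shown here alone, a single step between two halogens cannot show whether the numbers follow any wider order at this position, so it remains open how bromo, methyl, methoxy or an amine would compare with chloro and fluoro in the same place. Going by these compounds, it is also open whether the same swap would give a step of similar size and direction on a different core.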